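Thiazolyl for Trifluoromethyl: Cytotoxicity Outlook

A few compounds are considered here, and "the series" means these few. Any claim that something is new, unique, unknown or untested is made for them only; others in the source may bear on it.

Compound 1 `Cc1nn(Cc2nc3ccccc3n2CCCCO)c2ccccc12` sits at the limit > 100000 nM in an ADME assay on HEp-2 cells (Homo sapiens) for cytotoxicity, read by CCK-8 assay, with a stated time of 5 days; a higher number here means that more compound is tolerated, a lower number that less compound is tolerated.
Compound 2 `OCCCCn1c(Cn2ncc3ccncc32)nc2ccccc21` sits at the limit > 100000 nM in this assay.
Compound 3 `OCCCCn1c(Cn2c(C(F)(F)F)nc3ccccc32)nc2ccccc21` sits at the limit > 100000 nM in this assay.

Each of these three values is a limit of the assay and not a number: the cells tolerated as much compound as was tested. Compound 3 therefore stands where the other two stand, at the ceiling of what this assay can report, and nothing separates the three (the limit of > 100000 nM in this assay, at which 3 of the 3 values shown sit).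

Compound 4 `OCCCCn1c(Cn2c(-c3cscn3)nc3ccccc32)nc2ccccc21` is the next compound, not yet measured. It differs from compound 3 in one place: 1,3-thiazol-4-yl in place of trifluoromethyl on an aromatic carbon. For the measured compounds named here, no step between measured compounds is available, so the size of this change cannot be read from the data. With all three measured compounds at the ceiling, the expectation for compound 4 is no step beyond the usual scatter, which means an estimated step of a number no higher from compound 3 to compound 4 (the limit leaves the size open). Compound 4 is thus expected at about 100000 nM, somewhere between 40000 nM and 300000 nM, most likely reported again only as a limit.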

Compound 4, half-maximal cytotoxic concentration: > 100000 nM
Compound 4 gave a limit, no number (the forecaster's own chance of this, stated with the estimate: 80%); the middle value sits exactly at the limit.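

Compound 3 and compound 4 each give only a limit, so no step between them can be read, and the size of placing 1,3-thiazol-4-yl where trifluoromethyl stood stays unknown: the limit of > 100000 nM in this assay, at which 4 of the 4 values shown sit.

The compounds shown leave open what concentration of any of them the cells would fail to tolerate in this assay.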